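Piperazinyl replacing ethylamino on the shared core of compound 2

A few compounds are considered here, and "the series" means these few. Any claim that something is new, unique, unknown or untested is made for them only; others in the source may bear on it.

Three compounds are measured in a functional assay on U-937 cells (Homo sapiens) for cytotoxicity, read by MTT assay, with a stated time of 3 days; on this read-out higher numbers stand for weaker inhibition and lower numbers for stronger inhibition. Compound 1 `N#Cc1c(NN)nc(SCc2nc3ccccc3[nH]2)nc1-c1ccccc1` gives 3.9 nM. Compound 2 `CCNc1nc(SCc2nc3ccccc3[nH]2)nc(-c2ccccc2)c1C#N` gives 2.63 nM, and compound 3 `N#Cc1c(NC(N)=O)nc(SCc2nc3ccccc3[nH]2)nc1-c1ccccc1` gives 3.37 nM. Compound 2 has the lowest of the three numbers, but its gaps to compound 3 and to compound 1 are within the scatter, so no order among the three is established. The steps of a 1.5-fold lower number from compound 1 to compound 2 (0.17 log units; within the scatter), a 1.2-fold lower number from compound 1 to compound 3 (0.06 log units; within the scatter) and a 1.3-fold higher number from compound 2 to compound 3 (0.11 log units; within the scatter) each exchange one group on a nitrogen attached to the shared core, and all stay within the scatter.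

Compound 4 `N#Cc1c(-c2ccccc2)nc(SCc2nc3ccccc3[nH]2)nc1N1CCNCC1` is not yet measured. It differs from compound 2 by piperazin-1-yl in place of ethylamino on an aromatic carbon. Within the data shown here, no measured step covers a change of this kind: the three exchanges on record vary what hangs on an attached nitrogen, whereas here the ethylamino leaves and piperazin-1-yl enters directly on the aromatic carbon. The only bearing is indirect: three different groups at the same place gave numbers within the scatter of one another, so a small step in this assay is expected, with a wider range for the untested ring. Compound 4 is expected to give 3.5 nM in this assay, with a range from 1.3 nM to 10 nM. The expected step of a 1.3-fold higher number from compound 2 to compound 4 (0.12 log units; within the scatter) is estimated to stay within the scatter.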

Compound 4, half-maximal inhibitory concentration: 5.81 nM
Estimate against measurement, compound 4: 1.7-fold (0.22 log units) below; low and high end bracket the measured number.
By their numbers in this assay, from the lowest: compounds 2, 3, 1 and 4 (each within the scatter of the next, the first and the last beyond it).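

Piperazin-1-yl in place of ethylamino on the aromatic carbon gives the first step at this position that lies beyond the scatter in this assay (a 2.2-fold higher number from compound 2 to compound 4 (0.34 log units; beyond the scatter)), although it is only a modest one. The two other steps to the ring stay within the scatter (a 1.7-fold higher number from compound 3 to compound 4 (0.24 log units; within the scatter); a 1.5-fold higher number from compound 1 to compound 4 (0.17 log units; within the scatter)), so a separation appears only against ethylamino and not against the other two groups. No measurement at hand accounts for this step.

From the compounds shown here alone, whether the step follows from the ring itself or from its second nitrogen remains open, and piperidine or morpholine on the same aromatic carbon would bear on that. A longer chain such as butylamino would show whether an open chain of greater size at this position gives a similar step.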